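Fluoro for methoxy: compound 3 to compound 4 in this series

The compounds below may be only part of what the source reports. "The series", "measured", "known", "first", "only" and "open" are said of these compounds alone.

Compound 1 `Cc1c(-c2ccc(F)cc2)cc(C(=O)NC2CCCCCC2)c(=O)n1Cc1ccc(F)cc1` gives 600 nM in an assay on HEK293 cells for inhibition of Lysophosphatidylserine lipase ABHD12 (Homo sapiens), read by scintillation counting, with stated times of 30 min and 5 min; on this read-out lower numbers stand for stronger inhibition and higher numbers for weaker inhibition. For compound 2 `Cc1c(Br)cc(C(=O)NC2CCCCCC2)c(=O)n1Cc1ccc(F)cc1` this assay reports only a limit, > 10000 nM. The step of an at least 16-fold higher number from compound 1 to compound 2 (1.22 log units; beyond the scatter) is large and ends at the limit of > 10000 nM in this assay, at which 2 of the 3 values shown sit. For compound 3 `COc1ccc(-c2cc(C(=O)NC3CCCCCC3)c(OCc3ccc(F)cc3)nc2C)cc1` this assay again reports only a limit, > 10000 nM. Compound 4 `Cc1nc(OCc2ccc(F)cc2)c(C(=O)NC2CCCCCC2)cc1-c1ccc(F)cc1` differs from compound 3 by fluoro in place of methoxy on an aromatic carbon. Going by the values given here, the single measured step, an at least 16-fold higher number from compound 1 to compound 2 (1.22 log units; beyond the scatter), exchanges the whole 4-fluorophenyl and so does not bear directly on this change; compound 1 carries the entering 4-fluorophenyl, but on a different core, so no comparable step exists. Compound 4 is therefore expected near 6000 nM, between 1500 nM and 20000 nM, an expected step of an at least 1.6-fold lower number from compound 3 to compound 4 (0.22 log units; that floor lies within the scatter), with a real chance that this assay once more reports only a limit.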

Compound 4, half-maximal inhibitory concentration: > 10000 nM
Compound 4: only a limit was reported (the forecaster's own chance of this, stated with the estimate: 45%); at least 1.6-fold (0.22 log units) between middle value and limit.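

Compound 3 and compound 4 are both reported only as limits, and the step between them cannot be read. Still open, on these data alone, is whether 4-methoxyphenyl and 4-fluorophenyl differ at all in inhibition on this shared core.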